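Chloro to methyl on the aryl amide of a spirocyclic core

The compounds below may be only part of what the source reports. "The series", "measured", "known", "first", "only" and "open" are said of these compounds alone.

Measured compounds:
Compound 1, `O=C(c1cc(Cl)ccc1-c1ncccn1)N1CC2(CC2)C[C@H]1CNc1cc(C(F)(F)F)ccn1`: 7.1
Compound 2, `O=C(c1cc(Cl)ccc1-c1ncccn1)N1CC2(CC2)C[C@H]1CNc1ccc(C(F)(F)F)cn1`: 7.2
Compound 3, `Cc1ccc(OCc2ccccc2)c(C(=O)N2CC3(CC3)C[C@H]2CNc2ccc(C(F)(F)F)cn2)n1`: 8.6

In a functional assay on HEK293 cells for antagonist activity at Orexin receptor type 2 (Homo sapiens), read by FLIPR and calcium flux (a lower number here means a less potent compound, a higher number a more potent compound, by a factor of ten per unit of this negative logarithm), compound 1 gives 7.1 and compound 2 gives 7.2. For the measured compounds named here, the one step measured between neighbours, a number 0.10 log units higher from compound 1 to compound 2 (within the scatter), is within the scatter. Going by the values given here, compound 2 stands second of the three numbers, close to compound 1, while compound 3, which carries a different aryl amide altogether, gives 8.6 in this assay, a number higher than that of compound 2 by more than the scatter; no single step links compound 3 to compound 2.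

Compound 4, `Cc1ccc(-c2ncccn2)c(C(=O)N2CC3(CC3)C[C@H]2CNc2ccc(C(F)(F)F)cn2)c1`, is yet to be measured in this assay. It differs from compound 2 by methyl in place of chloro on an aromatic carbon. No measured step bears on this exchange: the only step shown moves the trifluoromethyl around the pyridine ring, and compound 3 differs from compound 2 in more than one place. With nothing to point either way, compound 4 is expected to sit near compound 2, with the step of no change at the digits printed from compound 2 to compound 4 (within the scatter) estimated as none beyond the scatter. For compound 4 the estimate is 7.2, ranging from 6.6 to 7.8.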

Compound 4, negative logarithm of the antagonist equilibrium constant: 6.6
The estimate for compound 4 lay 0.60 log units above the measured number; low and high end bracket the measured number.
By their numbers in this assay, from the lowest: compound 4; then compounds 1 and 2 (each within the scatter of the next); then compound 3.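

In this assay, methyl in place of chloro gives a number 0.60 log units lower from compound 2 to compound 4 (beyond the scatter), so this aromatic carbon, meta to a large group and para to a pyrimidin-2-yl group, is a place where a change of one heavy atom shows in the number, something the earlier step, confined to moving the trifluoromethyl around the pyridine, could not show. The counts do not separate the two groups: chloro and methyl each bring one heavy atom, no ring, no hydrogen-bond donors or acceptors and no net charge, so the step belongs to the identity of the group and not to anything those counts record. Nothing at hand says what about the exchange lies behind the step.

With only chloro and methyl at this carbon, the compounds shown leave open how a fluoro, a methoxy or a nitrile group there would compare with either. They also leave open whether the same exchange gives a similar step when the amine nitrogen carries the 4-(trifluoromethyl)pyridin-2-yl group of compound 1.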